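Moving the pyrazole attachment point in an acyl-CoA:cholesterol acyltransferase series

The source may report more compounds than this note shows. Statements on the series, on what has been measured and on what is new or still open speak of the compounds shown alone.

Compound 1, `Cc1cc(C)c(NC(=O)N(Cc2ccc(-c3n[nH]c(C)n3)cc2)C2CCCCCC2)c(C)c1`: 120 nM
Compound 2, `Cc1cc(C)c(NC(=O)N(Cc2ccc(N3CCN(C)CC3)cc2)C2CCCCCC2)c(C)c1`: 57 nM
Compound 3, `Cc1cc(C)c(NC(=O)N(Cc2ccc(-c3ccnn3C)cc2)C2CCCCCC2)c(C)c1`: 24 nM

Three ureas sharing one core were measured in an assay on microsomes from intestine for inhibition of acyl-CoA:cholesterol acyltransferase (Oryctolagus cuniculus); on this read-out higher numbers stand for weaker inhibition and lower numbers for stronger inhibition. Compound 3 holds the lowest number of the three: the step from compound 1 to compound 3 was a 5.0-fold lower number from compound 1 to compound 3 (0.70 log units; beyond the scatter), and the step from compound 2 to compound 3 was a 2.4-fold lower number from compound 2 to compound 3 (0.38 log units; beyond the scatter), both beyond the scatter, so compound 3 is the strongest inhibitor shown. Compound 4, `Cc1cc(C)c(NC(=O)N(Cc2ccc(-c3cnn(C)c3)cc2)C2CCCCCC2)c(C)c1`, keeps every atom of compound 3 but joins them differently: 1-methyl-1H-pyrazol-4-yl in place of 1-methyl-1H-pyrazol-5-yl on an aromatic carbon.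

For the measured compounds named here, none of the measured steps changes the attachment point of a ring; each of them exchanges one whole group for another, and those exchanges ranged from a 2.1-fold lower number from compound 1 to compound 2 (0.32 log units; beyond the scatter) to a 5.0-fold lower number from compound 1 to compound 3 (0.70 log units; beyond the scatter). The present change is smaller in kind, so the expected step in this assay is a 1.7-fold higher number from compound 3 to compound 4 (0.22 log units; within the scatter), with a slight lean toward a higher number left open. Compound 4 is therefore estimated at 40 nM, within a range of 15 nM to 110 nM.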

Compound 4, half-maximal inhibitory concentration: 47 nM
Beside the measured number, compound 4's estimate is 1.2-fold (0.07 log units) below it; measured number inside the range.
By their numbers in this assay, from the lowest: compounds 3, 4 and 2 (each within the scatter of the next, the first and the last beyond it); then compound 1.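

In this assay, for the compounds shown here, the swap of 1-methyl-1H-pyrazol-5-yl for 1-methyl-1H-pyrazol-4-yl, the first change of attachment point in this set, gives a 2.0-fold higher number from compound 3 to compound 4 (0.29 log units; within the scatter) and so does not separate the two pyrazoles at this position. The 1-methyl-1H-pyrazol-4-yl group set against 4-methylpiperazin-1-yl gives a 1.2-fold lower number from compound 2 to compound 4 (0.08 log units; within the scatter) and set against 5-methyl-1H-1,2,4-triazol-3-yl gives a 2.6-fold lower number from compound 1 to compound 4 (0.41 log units; beyond the scatter), so of these groups only the triazole stands clear of it. Nothing shown here accounts for any of these differences.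

As far as these compounds go, whether the remaining attachment, 1-methyl-1H-pyrazol-3-yl, would read alike stays open. So does the effect of replacing the methyl on the pyrazole nitrogen with hydrogen or an ethyl group.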